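Tert-Butyl Amide Expected to Track Its Smaller Analogues

This account rests on a few compounds, and the source may have more. Where it says the series, first, only, none or still open, it means among the compounds named here.

Three compounds share one core and differ only in what sits on the amide-type nitrogen. Compound 1 `Cc1cc(C(=O)NN2CCOCC2)nn1Cc1cc(Cl)cc2cc(-c3ccccc3)oc12` carries a morpholin-4-yl group there, compound 2 `Cc1cc(C(=O)NC(C)C)nn1Cc1cc(Cl)cc2cc(-c3ccccc3)oc12` an isopropyl group, and compound 3 `Cc1cc(C(N)=O)nn1Cc1cc(Cl)cc2cc(-c3ccccc3)oc12` a plain hydrogen. In an assay on CHO-K1 cells for displacement of a labelled ligand from prostaglandin E2 receptor EP1 subtype (Homo sapiens), read by scintillation counting, with a stated time of 45 min (on this read-out higher numbers stand for weaker inhibition and lower numbers for stronger inhibition), compound 1 gives 10 nM, compound 2 gives 10 nM, and compound 3 gives 5.01 nM. Compound 3 therefore holds the lowest of the three numbers, yet each gap to it lies within the scatter: a 2.0-fold lower number from compound 1 to compound 3 (0.30 log units; within the scatter), a 2.0-fold lower number from compound 2 to compound 3 (0.30 log units; within the scatter), and between the two substituted amides no change at the digits printed from compound 1 to compound 2 (within the scatter).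

Compound 4 `Cc1cc(C(=O)NC(C)(C)C)nn1Cc1cc(Cl)cc2cc(-c3ccccc3)oc12` extends this series: tert-butyl in place of hydrogen on an amide-type nitrogen. Among the measured compounds shown here, the steps that bear on it are the two that dressed the same nitrogen with isopropyl or morpholin-4-yl, and neither of them moved the number beyond the scatter. With nothing in the measured set pointing to a larger effect, compound 4 is expected to show a 2.0-fold higher number from compound 3 to compound 4 (0.30 log units; within the scatter), a shift that stays within the scatter. Compound 4 is accordingly estimated at 10 nM, with a range from 4 nM to 25 nM.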

Compound 4, half-maximal inhibitory concentration: 10 nM
Estimate against measurement, compound 4: no gap at the digits printed; measured number inside the range.
By their numbers in this assay, from the lowest: compounds 3, 1, 2 and 4 (each within the scatter of the next).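

In this assay the tert-butyl step gives a 2.0-fold higher number from compound 3 to compound 4 (0.30 log units; within the scatter), so a group with no ring and no hydrogen-bond donors or acceptors on the amide-type nitrogen leaves the number where the isopropyl and morpholin-4-yl groups left it. The last methyl added to the isopropyl group gives no change at the digits printed from compound 2 to compound 4 (within the scatter), and exchanging morpholin-4-yl for tert-butyl gives no change at the digits printed from compound 1 to compound 4 (within the scatter), which shows that neither this further carbon nor this exchange of groups separates the compounds in this assay. Across hydrogen, isopropyl, morpholin-4-yl and tert-butyl, this position has so far produced no step beyond the scatter, and tert-butyl extends that flat picture to the largest all-carbon chain group shown here. Nothing in the available evidence explains why the number holds so steady on this nitrogen.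

The compounds shown leave open whether this flatness would survive a carboxylic acid, a basic amine or a longer chain carried on the same nitrogen, or a phenyl ring placed there. As far as these compounds go, all four compounds also keep the amide hydrogen, so what a second group on that nitrogen, such as a methyl in its place, would do remains unknown.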